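This account rests on a few compounds, and the source may have more. Where it says the series, first, only, none or still open, it means among the compounds named here.

Values in a functional assay on cells (Platelet, Homo sapiens) for inhibition; on this read-out higher numbers stand for weaker inhibition and lower numbers for stronger inhibition:
Compound 1 `CCOC(=O)c1ccc(-c2nn(Cc3ccccc3Cl)c3ccccc23)cc1`: > 10000 nM
Compound 2 `CCOC(=O)c1ccc(-c2nn(Cc3cccnc3)c3ccccc23)cc1`: > 10000 nM

In this assay, compound 2 gives only a limit, > 10000 nM, and no number. Compound 1 also gives only a limit, > 10000 nM.

The next step leads to compound 3 `CCOC(=O)c1ccc(-c2nn(Cc3ccncc3)c3ccccc23)cc1`, with this change: pyridin-4-yl in place of pyridin-3-yl on a saturated chain carbon bound to an aromatic nitrogen. In words, this is pyridin-4-yl in place of pyridin-3-yl on a saturated chain carbon bound to an aromatic nitrogen.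

Within the data shown here, the one measured step at this place is a step that the two limits leave unreadable from compound 1 to compound 2. The evidence so far consists of the limit of > 10000 nM in this assay, at which 2 of the 2 values shown sit. No measured step size can therefore be carried over, and no direction of change is expected in this assay. For compound 3, the expected value is 12000 nM, with an estimated range of 4000 nM to 30000 nM. The estimated change is a step that the limit leaves unreadable from compound 2 to compound 3, and another limit is the likeliest report.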

Compound 3, half-maximal inhibitory concentration: > 10000 nM
Compound 3 ended at the assay's limit; the forecaster's own chance of this, stated with the estimate: 80%; the middle value lies beyond the limit too.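

In this assay, among these compounds, compound 3 gives > 10000 nM, a limit and not a number, so no step from compound 1 or compound 2 to compound 3 can be read. The compounds shown leave open whether any group on the saturated chain carbon bound to an aromatic nitrogen gives a readable inhibition value.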